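The source may hold more compounds than are shown below. What is called first, only, known or untested is meant among the compounds shown, and "the series" means these compounds.

Measured compounds so far:
- compound 1 `N#Cc1cnc(NC(=O)N2CCN(c3ccc(Cl)c(Cl)c3)CC2)s1` — in a physicochemical assay for solubility, read by nephelometry, at pH 2 (on this read-out higher numbers stand for higher solubility and lower numbers for lower solubility), compound 1 gives < 1600 nM, which is a limit of the assay rather than a number.
- compound 2 `Cc1ccc(NC2CN(C(=O)Nc3ncc(Cl)s3)C2)cc1Cl` — in this assay compound 2 gives 1600 nM.
- compound 3 `Cc1ccc(OCCCc2nc3cc(Cl)cnc3[nH]2)cc1Cl` — in this assay compound 3 gives 1600 nM.

Compound 1 thus stands at the floor of what this assay reports: the limit of < 1600 nM in this assay, at which 1 of the 3 values shown sits. Going by the values given here, compounds 2 and 3 sit at the same number as that floor, so the three measured points give no spread at all, and no step between two measured compounds that differ in one place is available to show in which direction, or by how much, a change of this kind moves solubility.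

Compound 4 `N#Cc1cnc(NC(=O)N2CCN(c3cnc(Cl)c(Cl)c3)CC2)s1` differs from compound 1 in one place: 5,6-dichloropyridin-3-yl in place of 3,4-dichlorophenyl on an amine nitrogen in a ring — 5,6-dichloropyridin-3-yl in place of 3,4-dichlorophenyl on an amine nitrogen in a ring. With nothing measured to lean on, the working expectation is a small step upward in this assay, of a size that need not clear the usual scatter, and with a fair chance that the assay again reports only its limit. Compound 4 is estimated at 2200 nM, with a range from 900 nM to 6000 nM. The step expected is an at least 1.3-fold higher number from compound 1 to compound 4 (0.13 log units; that floor lies within the scatter).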

Compound 4, solubility: < 1600 nM
Compound 4 was reported as a limit (the forecaster's own chance of this, stated with the estimate: 45%); at least 1.3-fold (0.13 log units) between middle value and limit.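

Compound 1 and compound 4 are both reported only as limits in this assay, so no step can be read between them: the limit of < 1600 nM in this assay, at which 2 of the 4 values shown sit.

The compounds shown leave open whether 5,6-dichloropyridin-3-yl in place of 3,4-dichlorophenyl on an amine nitrogen in a ring moves the read-out of this assay at all, and in which direction.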